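Chalcone triazole series: halogen swap on the benzyl ring

The source may hold more compounds than are shown below. What is called first, only, known or untested is meant among the compounds shown, and "the series" means these compounds.

Measured so far in a functional assay on HepG2 cells (Homo sapiens) for inhibition, read by MTT assay, with a stated time of 48 h, tested at 10 uM; a higher number here means more inhibition of growth at the concentration tested, a lower number less inhibition of growth:
compound 1 `O=C(/C=C/c1ccc(OCc2cn(Cc3ccccc3F)nn2)cc1)c1ccc(Br)cc1` gives 29%
compound 2 `O=C(/C=C/c1ccc(OCc2cn(Cc3ccccc3Br)nn2)cc1)c1ccc([N+](=O)[O-])cc1` gives 32%

Compound 2 carries the top number of the two, but compound 1 sits within the scatter of it, so the two cannot be told apart on this assay. Going by the values given here, no step between measured compounds is defined, since compound 1 and compound 2 differ in two places at once.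

Compound 3 `O=C(/C=C/c1ccc(OCc2cn(Cc3ccccc3F)nn2)cc1)c1ccc([N+](=O)[O-])cc1` is not yet measured. It is reached from compound 2 by fluoro in place of bromo on an aromatic carbon. The remainder of the molecule, including the nitro group on the benzoyl side, stays as in compound 2. Compound 1 already carries the 2-fluorobenzyl group and differs from compound 3 only on the benzoyl side; its number in this assay is close to that of compound 2.

With both measured numbers so near each other, no step beyond the scatter is expected in this assay; the expected step of a number 2 percentage points lower from compound 2 to compound 3 (within the scatter) is small, either way. Compound 3 is estimated at 30%, with a range from 16% to 44%.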

Compound 3, percent growth inhibition at one concentration: 22%
For compound 3 the middle estimate is 8 percentage points above the measured one; low and high end bracket the measured number.
By their numbers in this assay, from the lowest: compounds 3, 1 and 2 (each within the scatter of the next).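

In this assay, going by these compounds alone, the exchange of bromo for fluoro on the 2-substituted benzyl ring, with the nitro group held in place, gives a number 10 percentage points lower from compound 2 to compound 3 (within the scatter); this is the first reading of a single change at this position, ortho to a large group, and it does not separate the 2-bromobenzyl compound from the 2-fluorobenzyl compound. Within the data shown here, with the 2-fluorobenzyl group held instead, nitro in place of bromo on the benzoyl side gives a number 7 percentage points lower from compound 1 to compound 3 (within the scatter), so neither of the two places shows a step beyond the scatter so far. No data at hand speak to the origin of either step.

The compounds shown leave open whether a group other than a halogen at the benzyl position, such as an amine or a carboxylic acid, would give a step beyond the scatter in this assay. They also leave open whether an amine or a methoxy group on the benzoyl side would do so, as only bromo and nitro appear at that place.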